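Amide heteroaryl swap on the aminoethyl linker

The compounds below may be only part of what the source reports. "The series", "measured", "known", "first", "only" and "open" are said of these compounds alone.

Compound 3 `COc1ccc(C(=O)NCCNc2nc3cc(C)cc(C)c3cc2C#N)c(OC)c1` carries the larger of the two numbers in hand, though the gap to compound 2 lies within the scatter: in an in vitro assay on FRT cells with Cystic fibrosis transmembrane conductance regulator variant F508del (Homo sapiens) as the target, read by fluorescence, with a stated time of 24 h, at 37 degrees C, in the presence of a further agent that is not named here (on this read-out lower numbers stand for an effect already at smaller amounts and higher numbers for an effect only at larger amounts of compound), compound 3 gives 4200 nM. Compound 2 `Cc1cc(C)c2cc(C#N)c(NCCNC(=O)c3cccnc3)nc2c1` gives 2700 nM, and the step from compound 2 to compound 3 is a 1.6-fold higher number from compound 2 to compound 3 (0.19 log units; within the scatter). Compound 1 `Cc1cc(C)c2cc(C#N)c(NCCNC(=O)c3ccccn3)nc2c1` is reported as "not active" (no number reported), with no number. Compound 4 `Cc1cc(C)c2cc(C#N)c(NCCNC(=O)c3cnccn3)nc2c1` differs from compound 3 by pyrazin-2-yl in place of 2,4-dimethoxyphenyl on a carbonyl carbon. Within the data shown here, only the step from pyridin-3-yl to 2,4-dimethoxyphenyl bears on this change and it stayed within the scatter, so a return to a small heteroaryl ring is expected to shift the number no further than that; the entry for compound 1 leaves open that compound 4 may fall out of range. The expected step is a 1.2-fold higher number from compound 3 to compound 4 (0.08 log units; within the scatter). Compound 4 is estimated at 5000 nM, with a range from 1500 nM to 20000 nM.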

Compound 4, half-maximal effective concentration: 6700 nM
Compound 4: the middle estimate sits 1.3-fold (0.13 log units) below what was measured; low and high end bracket the measured number.
By their numbers in this assay, from the lowest: compounds 2, 3 and 4 (each within the scatter of the next, the first and the last beyond it).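

In this assay the place on the carbonyl carbon still yields a number with pyrazin-2-yl, a ring with 2 hetero atoms, and the swap for 2,4-dimethoxyphenyl reads as (a 1.6-fold higher number from compound 3 to compound 4 (0.20 log units; within the scatter)). Among these compounds, the swap for pyridin-3-yl gives the first step in this set beyond the scatter, though a modest one (a 2.5-fold higher number from compound 2 to compound 4 (0.39 log units; beyond the scatter)), so the choice between these two heteroaryl rings does register here. Nothing at hand accounts for either step. Open, as far as these compounds go, is what a morpholine ring would give on this carbonyl carbon, and what a longer chain would give in place of the aminoethyl linker.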